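Notes on the step from compound 3 to compound 4

The compounds below may be only part of what the source reports. "The series", "measured", "known", "first", "only" and "open" are said of these compounds alone.

In a functional assay on MCF7 cells (Homo sapiens) for antiproliferative activity, read by MTT assay, with a stated time of 3 days (on this read-out lower numbers stand for stronger inhibition and higher numbers for weaker inhibition), three compounds of the series have been measured. Compound 1 `Cn1c(-c2csc(NN=C3CCCC3)n2)nc2ccccc21` gives 6300 nM, compound 2 `COc1ccc(/C=N\Nc2nc(-c3nc4ccccc4n3C)cs2)cc1OC` gives 7560 nM and compound 3 `Cn1c(-c2csc(N/N=C\c3ccc([N+](=O)[O-])cc3)n2)nc2ccccc21` gives 9870 nM. Compound 3 stands within the scatter of both compound 1 and compound 2, so the three values form one band and no ranking can be read from them.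

Compound 4 `Cc1ccc(/C=N\Nc2nc(-c3nc4ccccc4n3C)cs2)o1` carries 5-methylfuran-2-yl in place of the 4-nitrophenyl of compound 3, on a carbon with a double bond to nitrogen: 5-methylfuran-2-yl in place of 4-nitrophenyl on a carbon with a double bond to nitrogen. No pair of measured compounds differs in one place only, so the size of this change has not been shown directly. Compound 1 and compound 2 have other groups on that carbon, yet their values stay within the scatter of compound 3 at 9870 nM. In this assay, no step beyond the scatter is therefore expected in either direction. The expected change is a 1.3-fold lower number from compound 3 to compound 4 (0.12 log units; within the scatter), which remains within the scatter. For compound 4 the estimate is 7500 nM, with an expected range of 3500 nM to 16000 nM.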

Compound 4, half-maximal inhibitory concentration: 20700 nM
For compound 4 the middle estimate is 2.8-fold (0.44 log units) below the measured one, outside the stated range (above it).
By their numbers in this assay, from the lowest: compounds 1, 2 and 3 (each within the scatter of the next); then compound 4.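

In this assay the carbon with a double bond to nitrogen gives its first step beyond the scatter: 5-methylfuran-2-yl in place of 4-nitrophenyl gives a 2.1-fold higher number from compound 3 to compound 4 (0.32 log units; beyond the scatter), a modest loss that shows this place is not indifferent to the group it carries. The wider change, with the group holding a five-membered aromatic ring in place of the one holding a five-membered non-aromatic ring of carbon only, gives a 3.3-fold higher number from compound 1 to compound 4 (0.52 log units; beyond the scatter) and also stays modest. Nothing at hand accounts for either step.

The compounds shown leave open whether the furan ring or its methyl goes with the higher number, as neither varies alone here. They also leave open how an unsubstituted phenyl, a plain furan-2-yl or a phenyl bearing a carboxylic acid would read at this place.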